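The source may hold more compounds than are shown below. What is called first, only, known or untested is meant among the compounds shown, and "the series" means these compounds.

For the measured compounds named here, in a functional assay on HepG2 cells (Homo sapiens) for inhibition, read by fluorescence and resazurin assay, with a stated time of 72 h (on this read-out lower numbers stand for stronger inhibition and higher numbers for weaker inhibition), the only numbers so far are for compound 1 (`O=C(Nc1ccc(Nc2nccc(Nc3ccc4cn[nH]c4c3)n2)cc1)Nc1cccc(F)c1`), which gives 6600 nM and compound 2 (`O=C(Nc1ccccc1)Nc1cccc(Nc2nccc(Nc3ccc4[nH]ncc4c3)n2)c1`), which gives 8100 nM in the same test. Compound 2 therefore stands within the scatter of compound 1. Going by the values given here, these two compounds differ in more than one place, so the series offers no single-change step to scale from. Compound 3 (`Cn1cc2ccc(Nc3ccnc(Nc4cccc(NC(=O)Nc5ccccc5)c4)n3)cc2n1`) departs from compound 2 in one place, on a nitrogen on an aromatic ring (2-methyl-2H-indazol-6-yl in place of 1H-indazol-5-yl on a nitrogen on an aromatic ring). Among the compounds with values here, with no measured precedent for this change, no step beyond the scatter is expected in this assay. The expectation starts from compound 2 at 8100 nM as its anchor. The expected size of the change is small (a 1.2-fold lower number from compound 2 to compound 3 (0.06 log units; within the scatter)). Within the data shown here, the range stays wide, as only two measured compounds support it. For compound 3 the estimated value is 7000 nM with an expected range from 2500 nM to 20000 nM on this read-out.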

Compound 3, half-maximal inhibitory concentration: 12000 nM
Compound 3: middle estimate off by 1.7-fold (0.23 log units), on the low side; low and high end bracket the measured number.
By their numbers in this assay, from the lowest: compounds 1, 2 and 3 (each within the scatter of the next).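

In this assay, 2-methyl-2H-indazol-6-yl in place of 1H-indazol-5-yl on a nitrogen on an aromatic ring gives a 1.5-fold higher number from compound 2 to compound 3 (0.17 log units; within the scatter), the first single-change step available in this series. This position therefore tolerates this exchange without a step beyond the scatter, even though the exchange alters both the point of attachment and the methyl substitution at once. No measured evidence bears on the origin of this small step.

For the compounds shown here, the single step cannot separate the contribution of the shifted attachment from that of the methyl group. Also open, as far as these compounds go, is whether a different group on this ring, such as a longer alkyl chain, an amine or a carboxylic acid, would produce a step beyond the scatter.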